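The source may report more compounds than this note shows. Statements on the series, on what has been measured and on what is new or still open speak of the compounds shown alone.

Of the compounds shown here, three have so far been tested in a functional assay on HCT-116 cells (Homo sapiens) for cytotoxicity, read by crystal violet staining and colony formation, with a stated time of 7 days; a lower number here means a stronger inhibitor, a higher number a weaker inhibitor. Compound 1 `COc1cccc(C2CC(c3c(O)ccc4ccccc34)=NN2)c1OC` gives 6300 nM in this assay, compound 2 `COc1ccc(C2CC(c3c(O)ccc4ccccc34)=NN2)c(OC)c1` gives 2400 nM, and compound 3 `COc1ccccc1C1CC(c2ccc3ccccc3c2O)=NN1` gives 17400 nM. Compound 3 therefore has the highest number of the three and is the weakest inhibitor among them: compound 1 lies nearest to it, compound 2 furthest, and both gaps are beyond the usual scatter of repeated measurements.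

Compound 4 `COc1ccc(C2CC(c3ccc4ccccc4c3O)=NN2)cc1` has not yet been measured. It differs from compound 3 in a single place: 4-methoxyphenyl in place of 2-methoxyphenyl on a saturated ring carbon. Among the measured compounds shown here, compound 1 and compound 2 differ from compound 3 in more than one place, so no measured pair isolates this change; their values show only that the numbers across this series run from those of compound 2 to those of compound 3.

Given that compound 3 gives 17400 nM and stands at the weak end of the series, the step from compound 3 to compound 4 is expected to be a 2.2-fold lower number from compound 3 to compound 4 (0.34 log units; beyond the scatter), a moderate move toward lower numbers, though it may well stay within the scatter. Compound 4 is thus estimated to give 8000 nM, with a plausible range from 3000 nM to 20000 nM.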

Compound 4, half-maximal inhibitory concentration: 13200 nM
For compound 4 the middle estimate is 1.7-fold (0.22 log units) below the measured one, within the range that was stated.
By their numbers in this assay, from the lowest: compound 2; then compound 1; then compounds 4 and 3 (each within the scatter of the next).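

In this assay, putting 4-methoxyphenyl in place of 2-methoxyphenyl on the saturated ring carbon gives a 1.3-fold lower number from compound 3 to compound 4 (0.12 log units; within the scatter), so the two compounds cannot be told apart in this read-out. Among the compounds shown here, this is the first pair that differs in one place only, and it shows that, with the same atoms in both compounds, these two placements of the methoxy group on the phenyl ring give numbers within the usual scatter of each other. No measurement shown here offers any explanation for this result.

The lower numbers of compound 1 and compound 2 remain untraced, since each differs from compound 3 and from compound 4 in more than one place, and so neither can be tied to a single change. Also open, as far as these compounds go, is how 3-methoxyphenyl would read at this ring carbon, and whether replacing the methoxy group on the phenyl ring with a different group, such as a chlorine atom, a hydroxyl or an amine, would give a number beyond the scatter.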